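Substituent variation on the aromatic nitrogen of the shared core

This account rests on a few compounds, and the source may have more. Where it says the series, first, only, none or still open, it means among the compounds named here.

Within the data shown here, in an assay on isolated protein for inhibition of Discoidin domain-containing receptor 2 (Homo sapiens), read by ELISA, with a stated time of 60 min (on this read-out lower numbers stand for stronger inhibition and higher numbers for weaker inhibition), compound 2 `Cc1ccc(C(=O)Nc2cccc(C(F)(F)F)c2)cc1-c1ccc2c(-c3cnn(C(C)C)c3)n[nH]c2c1` gives 7.7 nM, the higher of the two numbers so far; compound 1 `CCCn1cc(-c2n[nH]c3cc(-c4cc(C(=O)Nc5cccc(C(F)(F)F)c5)ccc4C)ccc23)cn1` gives 3.2 nM, and the step of a 2.4-fold higher number from compound 1 to compound 2 (0.38 log units; beyond the scatter) is modest. Compound 3 `Cc1ccc(C(=O)Nc2cccc(C(F)(F)F)c2)cc1-c1ccc2c(-c3cnn(CC(C)O)c3)n[nH]c2c1` carries the change (2-hydroxypropyl in place of isopropyl on an aromatic nitrogen). Among the measured compounds shown here, the only measured step at this aromatic nitrogen, from propyl to isopropyl, stayed modest, so a similarly small step is expected here, direction uncertain, most likely within or just beyond the scatter: compound 3 is estimated at 9 nM (range 3 nM to 30 nM), a step of a 1.2-fold higher number from compound 2 to compound 3 (0.07 log units; within the scatter) in this assay.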

Compound 3, half-maximal inhibitory concentration: 3.7 nM
Compound 3: middle estimate off by 2.4-fold (0.39 log units), on the high side; the range from low to high includes it.
By their numbers in this assay, from the lowest: compounds 1 and 3 (each within the scatter of the next); then compound 2.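

In this assay, the first polar substituent at this aromatic nitrogen gives a 2.1-fold lower number from compound 2 to compound 3 (0.32 log units; beyond the scatter), so the 2-hydroxypropyl chain recovers what the branched isopropyl group gave up. Against the unbranched chain, hydroxy in place of hydrogen gives a 1.2-fold higher number from compound 1 to compound 3 (0.06 log units; within the scatter), so this position accepts a hydroxy group on the chain with no change beyond the scatter. Nothing available explains either step.

On these data alone, whether the hydroxy group itself matters, or only its place on the chain, stays open. So does whether an amine, a carboxylic acid or a longer chain would be accepted here as well.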